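The source may hold more compounds than are shown below. What is called first, only, known or untested is meant among the compounds shown, and "the series" means these compounds.

Working notes on the series in a functional assay on HT-29 cells (Homo sapiens) for inhibition, read by sulforhodamine B assay, with a stated time of 48 h (on this read-out higher numbers stand for weaker inhibition of growth and lower numbers for stronger inhibition of growth), start from compound 3 (`CC(C)(C)NCc1c(C(=O)O)nn(-c2ccc(Cl)cc2)c1-c1ccccc1`). Compound 3 gives > 652000 nM as a limit, so it stands without a number. Compound 2 (`CC(C)(C)NCc1c(C(=O)O)nn(-c2ccc(Cl)cc2)c1-c1ccc(Br)cc1`) gives > 542000 nM as well, and this too is a limit. Compound 1 (`CCOC(=O)c1nn(-c2ccc(Cl)cc2)c(-c2ccc(OC)cc2)c1CNC(C)(C)C`) gives 45300 nM; > 523000 nM (2 entries) over two entries.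

The next compound, compound 4 (`COc1ccc(-c2c(CNC(C)(C)C)c(C(=O)O)nn2-c2ccc(Cl)cc2)cc1`), differs from compound 3 by methoxy in place of hydrogen on an aromatic carbon and reads as methoxy in place of hydrogen on an aromatic carbon, para to a large group, or phenyl to 4-methoxyphenyl.

Among the measured compounds shown here, the one measured step that bears on this is a step that the two limits leave unreadable from compound 2 to compound 3 and concerns the same aromatic carbon, but it gives no size to carry over. Compound 1 also holds the 4-methoxyphenyl group but differs elsewhere from compound 4, and its entries the several entries of compound 1 in this assay, 45300 nM; > 523000 nM (2 entries) do not agree with each other. With compound 2 and compound 3 both resting on limits, no size or direction can be drawn from them, and no step beyond the scatter is expected.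

The expected change is an at least 1.0-fold lower number from compound 3 to compound 4 (0.03 log units; that floor lies within the scatter) and would again probably appear as a limit. For compound 4 the estimate is 600000 nM with an expected range of 200000 nM to 1000000 nM in this assay.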

Compound 4, concentration for 50% growth inhibition: > 605000 nM
Compound 4 ended at the assay's limit; the forecaster's own chance of this, stated with the estimate: 85%; middle value at least 1.0-fold (0.00 log units) from the limit.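

In this assay compound 4 rests on a limit, as do compound 2 and compound 3, so no step can be read from compound 3 to compound 4 or from compound 2 to compound 4. The compounds shown leave open whether hydrogen, bromo and methoxy on this aromatic carbon differ in growth inhibition at all.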